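Swapping the aryl ring for a small amide

The compounds below may be only part of what the source reports. "The series", "measured", "known", "first", "only" and "open" are said of these compounds alone.

Of the compounds shown here, three sharing one core have been tested in an assay (Rattus norvegicus) for inhibition of Fatty-acid amide hydrolase 1 (Homo sapiens); on this read-out lower numbers stand for stronger inhibition and higher numbers for weaker inhibition. Compound 1 `O=C(CCCCCCc1ccccc1)c1ncc(-c2ccc(O)cc2)o1` gives 140 nM. Compound 2 `O=C(CCCCCCc1ccccc1)c1ncc(-c2ccncn2)o1` gives 2.3 nM. Compound 3 `O=C(CCCCCCc1ccccc1)c1ncc(-c2cncnc2)o1` gives 22 nM, which puts it second highest of the three numbers: the step of a 9.6-fold higher number from compound 2 to compound 3 (0.98 log units; beyond the scatter) separates it from the strongest compound, and the step of a 6.4-fold lower number from compound 1 to compound 3 (0.80 log units; beyond the scatter) separates it from compound 1. The two remaining steps, a 61-fold lower number from compound 1 to compound 2 (1.78 log units; beyond the scatter) and a 9.6-fold higher number from compound 2 to compound 3 (0.98 log units; beyond the scatter), show that the group on this carbon of the core moves the read-out strongly.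

Compound 4 `CNC(=O)c1cnc(C(=O)CCCCCCc2ccccc2)o1` carries a change of a different kind: methylcarbamoyl in place of pyrimidin-5-yl on an aromatic carbon. For the measured compounds named here, no measured step exchanges a ring for a chain-like group at this carbon, so the measured steps only show that this carbon is sensitive, not in which direction a group without a ring will act. With the ring removed, a number somewhat higher than that of compound 3 is expected, in size a modest step of a 1.8-fold higher number from compound 3 to compound 4 (0.26 log units; within the scatter) in this assay. The estimate for compound 4 is 40 nM, within a range from 8 nM to 200 nM.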

Compound 4, inhibition constant: 7 nM
Compound 4: the middle estimate sits 5.7-fold (0.76 log units) above what was measured; the whole stated range lies above it.
By their numbers in this assay, from the lowest: compound 2; then compound 4; then compound 3; then compound 1.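

A ring is not needed at this carbon of the shared core to keep a low number in this assay: methylcarbamoyl, which has no ring, gives a 3.1-fold lower number from compound 3 to compound 4 (0.50 log units; beyond the scatter) and also a 20-fold lower number from compound 1 to compound 4 (1.30 log units; beyond the scatter) against the hydroxyphenyl compound. The amide does not match the best ring, however, as the comparison with the pyrimidin-4-yl compound shows a 3.0-fold higher number from compound 2 to compound 4 (0.48 log units; beyond the scatter) and leaves compound 2 with the lowest number of the four. For the compounds shown here, the numbers at this carbon therefore do not divide into ring groups on one side and a group without a ring on the other, since the single group without a ring ranks inside the spread of the three ring groups.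

With only one group of this kind shown, it stays open whether a primary amide, a carboxylic acid, an amine or a longer chain at this carbon would give a lower or a higher number. No other measurement accompanies these numbers, so what lies behind the lower number of the amide compared with the pyrimidin-5-yl ring remains unexplained.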